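Swapping the Urea Aryl Group of Compound 1

The source may report more compounds than this note shows. Statements on the series, on what has been measured and on what is new or still open speak of the compounds shown alone.

Compound 1 `O=C(Nc1cccc(-n2cc(-c3ccncc3)c(-c3ccc(Cl)c(O)c3)n2)c1)Nc1ccc(Cl)c(Cl)c1`: 12200 nM in a functional assay on SNB-75 cells (Homo sapiens) for inhibition, read by sulforhodamine B assay, with a stated time of 48 h; on this read-out lower numbers stand for stronger inhibition of growth and higher numbers for weaker inhibition of growth
Compound 2 `COc1cc(-c2nn(-c3cccc(NC(=O)c4ccc(Cl)c(C(F)(F)F)c4)c3)cc2-c2ccncc2)ccc1Cl`: 29200 nM
Compound 3 `COc1cc(-c2nn(-c3cccc(NC(=O)c4ccccc4)c3)cc2-c2ccncc2)ccc1Cl`: a limit of the assay, > 100000 nM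

Compound 1 gives the lowest of the two numbers, and the nearest measured neighbour, compound 2, sits a step above it. For compound 3 only a limit was reached (the limit of > 100000 nM in this assay, at which 1 of the 3 values shown sits), so no number exists for it. For the measured compounds named here, the one step that can be measured runs an at least 3.4-fold higher number from compound 2 to compound 3 (0.53 log units; beyond the scatter), where the substituted phenyl on the carbonyl carbon is replaced by plain phenyl; it shows that taking the chlorine and trifluoromethyl groups off that aryl ring weakens growth inhibition at least modestly.

Compound 4 `O=C(Nc1cccc(-n2cc(-c3ccncc3)c(-c3ccc(Cl)c(O)c3)n2)c1)Nc1cccc(C(F)(F)F)c1` differs from compound 1 only in the aryl group on the amide-type nitrogen of the urea: 3-(trifluoromethyl)phenyl in place of 3,4-dichlorophenyl on an amide-type nitrogen. Both groups are substituted phenyl rings, so the measured step does not directly apply, and the change keeps lipophilic substitution on that ring. A small weakening, near the scatter, is expected: a 1.5-fold higher number from compound 1 to compound 4 (0.17 log units; within the scatter). Compound 4 is therefore estimated at 18000 nM, with a range from 6000 nM to 50000 nM.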

Compound 4, concentration for total growth inhibition: > 32500 nM
Compound 4 ended at the assay's limit; the forecaster's own chance of this, stated with the estimate: 10%; middle value at least 1.8-fold (0.25 log units) away from the limit.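

In this assay compound 4 gives > 32500 nM, which is a limit of the assay and not a number. Even so, the change can be read as a clear loss: an at least 2.6-fold higher number from compound 1 to compound 4 (0.42 log units; beyond the scatter). The earlier step showed a loss only when the substituents on the aryl ring were removed altogether, and on a different linker, whereas this one shows that on the urea of compound 1 a substituted phenyl ring does not by itself keep the growth inhibition, so 3,4-dichlorophenyl and 3-(trifluoromethyl)phenyl are not interchangeable on this nitrogen.

Going by these compounds, how far compound 4 lies beyond its limit stays unknown, so the full size of the step is open. Also open, on these data alone, is whether a single chlorine would be enough on that ring, and how a cyclohexyl group, or a phenyl ring carrying an amine or a carboxylic acid, would behave on the same nitrogen.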